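Aryl swap on the triazole: cyano analogue of compound 2

A few compounds are considered here, and "the series" means these few. Any claim that something is new, unique, unknown or untested is made for them only; others in the source may bear on it.

Three compounds of this series share one core and differ only in the aryl group on the aromatic nitrogen of the triazole. Compound 1 `CC1(C)[C@H]2CC[C@]1(C)N(Cc1cn(-c3ccc(Cl)cc3)nn1)C(=O)C2` gives 410 nM in a functional assay on SGC-7901 cells (Homo sapiens) for inhibition, read by MTT assay, with a stated time of 24 h; on this read-out lower numbers stand for stronger inhibition and higher numbers for weaker inhibition; compound 2 `Cc1ccc(-n2cc(CN3C(=O)C[C@@H]4CC[C@@]3(C)C4(C)C)nn2)cc1` gives 390 nM; compound 3 `CC1(C)[C@H]2CC[C@]1(C)N(Cc1cn(-c3cccc(F)c3)nn1)C(=O)C2` gives 530 nM. Compound 2 shows the lowest number of the three, yet its gaps to the others, a 1.1-fold lower number from compound 1 to compound 2 (0.02 log units; within the scatter) and a 1.4-fold higher number from compound 2 to compound 3 (0.13 log units; within the scatter), both sit within the scatter, so no ordering can be read from them. The step of a 1.3-fold higher number from compound 1 to compound 3 (0.11 log units; within the scatter) is likewise within the scatter.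

Compound 4 `CC1(C)[C@H]2CC[C@]1(C)N(Cc1cn(-c3cccc(C#N)c3)nn1)C(=O)C2` is not yet measured. It differs from compound 2 by 3-cyanophenyl in place of 4-methylphenyl on an aromatic nitrogen. Going by the values given here, the steps that bear on it are the substituent swap between compound 1 and compound 2 and the change of aryl group from compound 2 to compound 3; neither moved the number beyond the scatter. On that basis compound 4 is expected to show no step beyond the scatter, a 1.3-fold higher number from compound 2 to compound 4 (0.11 log units; within the scatter), and its estimated value is 500 nM with a range from 250 nM to 1000 nM.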

Compound 4, half-maximal inhibitory concentration: 250 nM
Compound 4: the middle estimate sits 2.0-fold (0.30 log units) above what was measured, and the stated range covers the measured number.
By their numbers in this assay, from the lowest: compounds 4, 2, 1 and 3 (each within the scatter of the next, the first and the last beyond it).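

Working from this assay, the swap of fluoro for cyano on the aromatic carbon gives the first step in this aryl series to pass the scatter, though only modestly (a 2.1-fold lower number from compound 3 to compound 4 (0.33 log units; beyond the scatter)). The other two new steps stay within the scatter (a 1.6-fold lower number from compound 2 to compound 4 (0.19 log units; within the scatter)) and (a 1.6-fold lower number from compound 1 to compound 4 (0.21 log units; within the scatter)), so compound 4 cannot be ordered against compound 2 or compound 1, and the aryl group on the aromatic nitrogen accepts 3-cyanophenyl without a separable change from those two. No supporting data bear on why the cyano and fluoro compounds part.

From the compounds shown here alone, whether an amine or a carboxylic acid on that same aromatic carbon would extend or reverse the step remains open. So does the outcome of a longer alkyl chain in place of the aryl group on the aromatic nitrogen.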